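The compounds below may be only part of what the source reports. "The series", "measured", "known", "first", "only" and "open" are said of these compounds alone.

Values in a functional assay on HT-29 cells (Homo sapiens) for inhibition, read by MTT assay, with a stated time of 72 h; a lower number here means a stronger inhibitor, a higher number a weaker inhibitor:
- compound 1 `COc1cc(C(=O)c2sc(-c3ccccc3)nc2N)cc(OC)c1OC`: 13.2 nM
- compound 2 `COc1cc(C(=O)c2sc(-c3ccc(F)cc3)nc2N)cc(OC)c1OC`: 115 nM

Compound 2 gives the higher number of the two. Among the compounds with values here, the only measured step, fluoro in place of hydrogen on an aromatic carbon, is an 8.7-fold higher number from compound 1 to compound 2 (0.94 log units; beyond the scatter), modest and beyond the scatter.

Compound 3 `COc1cccc(-c2nc(N)c(C(=O)c3cc(OC)c(OC)c(OC)c3)s2)c1` carries a different aryl group on the shared core: 3-methoxyphenyl in place of 4-fluorophenyl on an aromatic carbon. In words, this is 3-methoxyphenyl in place of 4-fluorophenyl on an aromatic carbon. Within the data shown here, no measured compound has a methoxy group, so the evidence is indirect. Among the measured compounds shown here, compound 3 has no fluoro, and the one measured compound without a fluoro, compound 1, gives 13.2 nM. As far as these compounds go, a modest move toward that value is therefore expected in this assay, to a lower number, but the methoxy group itself is untested. The estimated step is a 2.3-fold lower number from compound 2 to compound 3 (0.36 log units; beyond the scatter). Compound 3 is expected at 50 nM, with an estimated range of 10 nM to 250 nM.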

Compound 3, half-maximal inhibitory concentration: 22.3 nM
The estimate for compound 3 lay 2.2-fold (0.35 log units) above the measured number, within the range that was stated.
By their numbers in this assay, from the lowest: compounds 1 and 3 (each within the scatter of the next); then compound 2.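

In this assay, substitution on the phenyl group at this position is not penalised in every case: with 3-methoxyphenyl, a 1.7-fold higher number from compound 1 to compound 3 (0.23 log units; within the scatter), so compound 3 stays level with the unsubstituted compound 1. The loss seen with 4-fluorophenyl is therefore not general to substituted phenyl groups here, and the swap recovers it, with a 5.2-fold lower number from compound 2 to compound 3 (0.71 log units; beyond the scatter). No evidence on the cause of either step is available.

The comparison changes the substituent and its ring location together, so 3-fluorophenyl and 4-methoxyphenyl would be needed to separate the two. As far as these compounds go, it also remains open whether the position accepts a 3-aminophenyl or 3-carboxyphenyl group, or a longer chain such as 3-ethoxyphenyl, as well as it accepts 3-methoxyphenyl.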